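The source may report more compounds than this note shows. Statements on the series, on what has been measured and on what is new or still open speak of the compounds shown alone.

Two ureas sharing one aryl half and differing only in the substituted naphthalene on the other half were measured in an in vitro functional assay on cells for antagonist activity at transient receptor potential cation channel subfamily V member 1 (Homo sapiens), read by reporter gene assay and calcium flux; on this read-out higher numbers stand for weaker inhibition and lower numbers for stronger inhibition. Compound 1 `O=C(Nc1ccc(Cl)c(C(F)(F)F)c1)Nc1cccc2cc(O)ccc12` gives 18 nM in this assay. Compound 2 `O=C(Nc1ccc(Cl)c(C(F)(F)F)c1)Nc1cccc2ccc(C(=O)O)cc12` gives 84 nM in this assay, the higher of the two numbers, and the gap to compound 1 lies beyond the usual scatter. The two compounds differ in both the group and its position on the naphthalene, so no single change accounts for that gap.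

Compound 3 `O=C(Nc1ccc(Cl)c(C(F)(F)F)c1)Nc1cccc2ccc(NCc3ccccc3)cc12` is the next compound to be measured. It differs from compound 2 in one place: benzylamino in place of carboxy on an aromatic carbon. Among the compounds with values here, with only two measured compounds and no one-place comparison among them, the size of this step can only be guessed. The acid is the weaker of the two measured compounds, and the author expects the step from compound 2 to compound 3 to be a moderate lowering of the number, a 2.8-fold lower number from compound 2 to compound 3 (0.45 log units; beyond the scatter). Compound 3 is accordingly estimated at 30 nM in this assay, with a plausible range from 8 nM to 150 nM.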

Compound 3, half-maximal inhibitory concentration: 140 nM
Estimate against measurement, compound 3: 4.7-fold (0.67 log units) below; the range from low to high includes it.
By their numbers in this assay, from the lowest: compound 1; then compounds 2 and 3 (each within the scatter of the next).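

Within the data shown here, the first one-place comparison in the set concerns this aromatic carbon, meta to a fused ring and para to a fused ring: in this assay, benzylamino in place of carboxy gives a 1.7-fold higher number from compound 2 to compound 3 (0.22 log units; within the scatter) and the two numbers cannot be told apart. Here, a group of 8 heavy atoms carrying a six-membered aromatic ring and a group of 3 heavy atoms with a double bond outside aromatic rings thus give no separable read-out at this carbon. No measurement is available that would explain this result.

Going by these compounds, whether a plain amino group, a methoxy group or a longer chain such as phenethylamino on this carbon would give a number separable from these two remains open. So does the outcome of placing hydroxy, the group carried by compound 1, on this same carbon.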